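Changing the Sulfonyl Aryl Group in a Bradykinin Series

The source may hold more compounds than are shown below. What is called first, only, known or untested is meant among the compounds shown, and "the series" means these compounds.

The three measured compounds share one core and differ only in the group on the sulfonyl sulfur. Compound 1 `CC(C)(C)NCc1ccc2c(c1)CCC[C@H]2NC(=O)C[C@@H]1CCCCN1S(=O)(=O)c1ccccc1` gives 1700 nM in an assay on isolated protein for inhibition of B1 bradykinin receptor (Homo sapiens); a higher number here means a weaker inhibitor, a lower number a stronger inhibitor. Compound 2 `CCCCOc1ccc(S(=O)(=O)N2CCCC[C@H]2CC(=O)N[C@@H]2CCCc3cc(CNC(C)(C)C)ccc32)cc1` gives 1200 nM in this assay, and the step of a 1.4-fold lower number from compound 1 to compound 2 (0.15 log units; within the scatter) is small. Compound 3 `Cc1ccc(S(=O)(=O)N2CCCC[C@H]2CC(=O)N[C@@H]2CCCc3cc(CNC(C)(C)C)ccc32)cc1Cl` gives 15 nM in this assay, the lowest number of the three; it stands apart from the others by a 110-fold lower number from compound 1 to compound 3 (2.05 log units; beyond the scatter) and by an 80-fold lower number from compound 2 to compound 3 (1.90 log units; beyond the scatter). Compound 4 `CC(C)(C)NCc1ccc2c(c1)CCC[C@H]2NC(=O)C[C@@H]1CCCCN1S(=O)(=O)c1cccc2cnccc12` carries isoquinolin-5-yl in place of 3-chloro-4-methylphenyl on a sulfonyl sulfur. For the measured compounds named here, the two steps that reach compound 3 show that the group on the sulfonyl sulfur can move the number a long way, yet neither involves a group with a ring containing a hetero atom, so no measured step fixes the direction for compound 4. Because the step of a 110-fold lower number from compound 1 to compound 3 (2.05 log units; beyond the scatter) shows how much was gained with the 3-chloro-4-methylphenyl group, giving that group up is expected to surrender part of the gain, and a weakening step an 8.0-fold higher number from compound 3 to compound 4 (0.90 log units; beyond the scatter) is expected in this assay. Compound 4 is therefore estimated at 120 nM, within the range 15 nM to 1000 nM.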

Compound 4, half-maximal inhibitory concentration: 610 nM
Beside the measured number, compound 4's estimate is 5.1-fold (0.71 log units) below it, and the stated range covers the measured number.
By their numbers in this assay, from the lowest: compound 3; then compounds 4, 2 and 1 (each within the scatter of the next, the first and the last beyond it).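

In this assay, isoquinolin-5-yl is the only group shown on the sulfonyl sulfur that has a ring with a hetero atom and a hydrogen-bond acceptor, and it does not hold the level of 3-chloro-4-methylphenyl, with a 41-fold higher number from compound 3 to compound 4 (1.61 log units; beyond the scatter) as a large step. Against the simpler groups it moves the number far less: a 2.8-fold lower number from compound 1 to compound 4 (0.45 log units; beyond the scatter) is a modest step, and a 2.0-fold lower number from compound 2 to compound 4 (0.29 log units; within the scatter) lies within the scatter. The large gain at this position therefore stays with compound 3 alone among the four compounds, and no evidence is available here to explain this result.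

The compounds shown leave open whether the chlorine, the methyl or both together account for the level of compound 3, which a 3-chlorophenyl or a 4-methylphenyl group on the sulfonyl sulfur would separate. They also leave open how the hetero atom of isoquinolin-5-yl counts, since no group with the same two rings of carbon only, such as naphthalen-1-yl, stands among them.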